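The source may report more compounds than this note shows. Statements on the series, on what has been measured and on what is new or still open speak of the compounds shown alone.

Measured in a physicochemical assay for solubility, in phosphate buffer, at pH 7.4; on this read-out lower numbers stand for lower solubility and higher numbers for higher solubility:
- compound 1 (`COCC1CCN(c2nccnc2OC2CN(c3ccc4ccccc4n3)C2)CC1`) gives 53000 nM
- compound 2 (`c1ccc2nc(N3CC(Oc4nccnc4N4CCCCC4)C3)ccc2c1`) gives < 1000 nM as a limit of the assay
- compound 3 (`NC(=O)C1CCN(c2nccnc2OC2CN(c3ccc4ccccc4n3)C2)CC1`) gives 14000 nM

Compound 3 holds the lower of the two true numbers. The step behind that position is modest (a 3.8-fold lower number from compound 1 to compound 3 (0.58 log units; beyond the scatter)). The remaining value is only a limit (the limit of < 1000 nM in this assay, at which 1 of the 3 values shown sits).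

Compound 4 (`c1ccc(-c2nccnc2OC2CN(c3ccc4ccccc4n3)C2)nc1`) carries pyridin-2-yl in place of 4-carbamoylpiperidin-1-yl on an aromatic carbon. Within the data shown here, no measured step makes this exact change, so the steps on the saturated ring are the nearest guide. Hydrogen in place of methoxymethyl was a large step (an at least 53-fold lower number from compound 1 to compound 2 (1.72 log units; beyond the scatter)). Compound 4 also lacks the carbamoyl, so with the large step seen on adding that group (an at least 14-fold higher number from compound 2 to compound 3 (1.14 log units; beyond the scatter)) a clearly lower number is expected in this assay and it may be reported only as a limit. The expected step is large (a 9.3-fold lower number from compound 3 to compound 4 (0.97 log units; beyond the scatter)). For compound 4 the estimated value is 1500 nM (expected range 400 nM to 8000 nM).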

Compound 4, solubility: 349000 nM
The estimate for compound 4 lay 230-fold (2.37 log units) below the measured number; measured number above the stated range.
By their numbers in this assay, from the lowest: compound 3; then compound 1; then compound 4. At a limit, below all of these: compound 2.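

In this assay, pyridin-2-yl on this aromatic carbon gives the highest number of the series, with a 25-fold higher number from compound 3 to compound 4 (1.40 log units; beyond the scatter) and a 6.6-fold higher number from compound 1 to compound 4 (0.82 log units; beyond the scatter). The earlier compounds shown here varied only the substituent on the saturated ring, whereas compound 4 shows that a high number at this position does not depend on keeping the saturated ring, carbamoyl or methoxymethyl. Against piperidin-1-yl the change gives an at least 340-fold higher number from compound 2 to compound 4 (2.54 log units; beyond the scatter), and compound 2 stands there only at a limit: the limit of < 1000 nM in this assay, at which 1 of the 4 values shown sits.

The compounds shown leave open whether the high number follows from the ring nitrogen of pyridin-2-yl or from any aromatic ring at this carbon, a question that a phenyl ring there would address. A morpholine at the same carbon would test whether a hetero atom inside a saturated ring gives a similar result.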